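Second Chloro on a Cytotoxic Purine-Type Series

The source may hold more compounds than are shown below. What is called first, only, known or untested is meant among the compounds shown, and "the series" means these compounds.

Measured compounds so far:
compound 1, `ClCc1ccccc1Cn1cnc2c(Cl)ncnc21`, 3160 nM
compound 2, `ClCc1cccc(Cn2cnc3ncnc(Cl)c32)c1`, 3380 nM
compound 3, `ClCc1cccc(Cn2cnc3c(Cl)ncnc32)c1`, 9330 nM

All three were tested in a functional assay on IGROV-1 cells (Homo sapiens) for cytotoxicity, read by sulforhodamine B assay, with a stated time of 48 h; a higher number here means a weaker inhibitor of growth, a lower number a stronger inhibitor of growth. Compound 1 gives 3160 nM and compound 2 gives 3380 nM, two numbers that lie within the usual scatter of each other, so no order between them can be read. Compound 3 gives 9330 nM, the highest of the three numbers; its gap to compound 2 and its gap to compound 1 both lie beyond the scatter, so compound 3 is the weakest growth inhibitor among the measured compounds. Going by the values given here, none of the three differs from another in a single place, so no single-point step can be drawn among them.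

Compound 4, `ClCc1cccc(Cn2cnc3c(Cl)nc(Cl)nc32)c1`, has not yet been measured. It differs from compound 3 by chloro in place of hydrogen on an aromatic carbon. Among the compounds with values here, no measured pair shows what such an added chloro does on this core, so the direction of the step is open. A step of modest size in either direction, or none beyond the scatter, is expected. The estimate for compound 4 in this assay is 6000 nM, with a range from 1500 nM to 25000 nM, which means an expected step of a 1.6-fold lower number from compound 3 to compound 4 (0.19 log units; within the scatter).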

Compound 4, concentration for 50% growth inhibition: 2290 nM
Estimate against measurement, compound 4: 2.6-fold (0.42 log units) above, and the stated range covers the measured number.
By their numbers in this assay, from the lowest: compounds 4, 1 and 2 (each within the scatter of the next); then compound 3.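

Putting chloro in place of hydrogen on the aromatic carbon between two ring nitrogen atoms gives a 4.1-fold lower number from compound 3 to compound 4 (0.61 log units; beyond the scatter) in this assay, so this position does respond to substitution, and here the response is stronger growth inhibition. Going by these compounds alone, this is the first step that changes only one place, and it gives the first direct reading of a change on this core: the entering chloro is 1 heavy atom, with no ring, no hydrogen-bond donors or acceptors and no net charge, yet the step lies beyond the scatter. Nothing measured here accounts for the step, so it stands as an observation without an explanation.

This single step cannot show whether chloro is special at this carbon, or whether an amine, a methoxy group or a fluoro group there would move the number in the same direction or by a similar amount. It also leaves open whether the same added chloro would give a similar step on compound 1 or compound 2, where the rest of the structure differs from compound 3.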